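Chloro to Nitro on a Pendant Aryl Ring

A few compounds are considered here, and "the series" means these few. Any claim that something is new, unique, unknown or untested is made for them only; others in the source may bear on it.

Measured compounds:
Compound 1, `CC(C)=CCC1Cc2c(OCCCNS(=O)(=O)c3ccc(Cl)cc3)cc(=O)n(CCCO)c2CC1(C)C`: 24.7%
Compound 2, `CC(C)=CCC1Cc2c(OCCCNS(=O)(=O)c3ccc([N+](=O)[O-])cc3)cc(=O)n(CCCO)c2CC1(C)C`: 47.7%
Compound 3, `CC(C)=CCC/C(C)=C/CC1Cc2c(OCCCOc3ccc(Cl)cc3)cc(=O)n(CCCO)c2CC1(C)C`: 25.2%

In a functional assay on PANC-1 cells (Homo sapiens) for inhibition, read by MTT assay, with a stated time of 24 h, tested at 10 uM (a lower number here means less inhibition, a higher number more inhibition at the concentration tested (going by the name of the read-out)), compound 1 gives 24.7% and compound 2 gives 47.7%. The two differ by nitro in place of chloro on an aromatic carbon, and this change made a number 23 percentage points higher from compound 1 to compound 2 (beyond the scatter). Compound 3 gives 25.2% in this assay, a number that sits within the scatter of compound 1; against compound 2 the number of compound 3 stands clearly lower. The difference between the core of compound 3 and that of compound 1 is not broken down here.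

Compound 4, `CC(C)=CCC/C(C)=C/CC1Cc2c(OCCCOc3ccc([N+](=O)[O-])cc3)cc(=O)n(CCCO)c2CC1(C)C`, has not yet been measured. It differs from compound 3 by nitro in place of chloro on an aromatic carbon. This is the same change as from compound 1 to compound 2, at a place described in the same words, though the wider surroundings read differently, sulfonyl in one pair and phenoxy in the other. Resting on the single step seen from compound 1 to compound 2, a number 23 percentage points higher from compound 1 to compound 2 (beyond the scatter), a rise is expected from compound 3 to compound 4 of about a number 16.8 percentage points higher from compound 3 to compound 4 (beyond the scatter), with wide room on either side since only one such step is known. Compound 4 is therefore estimated to give 42% in this assay, expected between 26% and 60%.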

Compound 4, a percentage reported as inhibition, at one concentration (the size of the read-out at that concentration, not a potency): 65.1%
Compound 4: the middle estimate sits 23.1 percentage points below what was measured; measured number outside the range, above it.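

In this assay, nitro in place of chloro on the aromatic carbon gave a number 39.9 percentage points higher from compound 3 to compound 4 (beyond the scatter), so the number rose on both cores, but not by the same amount: the same change on two cores in this assay, a number 23 percentage points higher (beyond the scatter) from compound 1 to compound 2 and a number 39.9 percentage points higher (beyond the scatter) from compound 3 to compound 4, 16.9 percentage points apart, beyond the scatter of two such steps In these two pairs the direction of the step carries from one core to the other, while its size does not, so a step read on one core gives no reliable size for the other. The two pairs do not show which of the structural differences between the cores goes with the gap, and two steps are too few to establish a rule for the series.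

The compounds shown leave open how a nitrile, a methoxy group or an amine at the same place would read on either core, and so whether the rise is particular to nitro. They also leave open whether the nitro step would rise on a third core, and by how much.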